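A few compounds are considered here, and "the series" means these few. Any claim that something is new, unique, unknown or untested is made for them only; others in the source may bear on it.

Series notes on the shared core. Within the data shown here, compound 1 `C=C1C[C@]23C[C@@]1(O)CC[C@H]2c1ccc(OS(=O)(=O)c2ccc(C)cc2)c(C)c1[C@@H]3Cn1cc(-c2ccc(OC)cc2)nn1` is the first member. In a functional assay on MCF7 cells (Homo sapiens) for cytotoxicity, read by MTT assay, with a stated time of 4 days (on this read-out higher numbers stand for weaker inhibition and lower numbers for stronger inhibition), compound 1 gives > 20000 nM, which is a limit of the assay and not a number. Compound 2 `C=C1C[C@]23C[C@@]1(O)CC[C@H]2c1ccc(O)c(C)c1[C@@H]3Cn1cc(-c2ccc(OC)cc2)nn1` differs from it in one place; in this assay compound 2 gives > 20000 nM, again a limit. The step that the two limits leave unreadable from compound 1 to compound 2 therefore cannot be sized, since both ends sit at the limit of > 20000 nM in this assay, at which 2 of the 3 values shown sit. Among the measured compounds shown here, compound 3 `C=C1C(=O)[C@]23C[C@@]1(O)CC[C@H]2c1ccc(OS(=O)(=O)c2ccc(C)cc2)c(C)c1[C@@H]3Cn1cc(-c2ccc(C)cc2)nn1` is the only member with a measured number: in this assay compound 3 gives 320 nM. Compound 4 `C=C1C(=O)[C@]23C[C@@]1(O)CC[C@H]2c1ccc(OS(=O)(=O)c2ccc(C)cc2)c(C)c1[C@@H]3Cn1cc(-c2ccccn2)nn1` has not yet been measured. The change from compound 3 is pyridin-2-yl in place of 4-methylphenyl on an aromatic carbon. No measured step touches the group on the triazole carbon; the one step shown concerns the oxygen on the aromatic ring and is unreadable, so it gives no guidance on direction or size here. With nothing to point either way, the estimated step of no change at the digits printed from compound 3 to compound 4 (within the scatter) is taken as none beyond the scatter. Compound 4 is expected near 320 nM, within 100 nM to 1000 nM.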

Compound 4, half-maximal inhibitory concentration: 320 nM
Compound 4: middle estimate and measured number agree at the digits printed; the measured number falls inside the stated range.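

Replacing 4-methylphenyl by pyridin-2-yl on an aromatic carbon of the five-membered aromatic ring with 3 nitrogen gives, in this assay, no change at the digits printed from compound 3 to compound 4 (within the scatter). Among these compounds, this is the first readable step and the first to touch this position, and it shows that the reading holds when the carbon-only ring gives way to a ring with 1 hetero atom that brings a hydrogen-bond acceptor. The one earlier step cannot be read, since both of its ends are limits: the limit of > 20000 nM in this assay, at which 2 of the 4 values shown sit.

Open, going by these compounds, is how a carboxylic acid, an aliphatic amine or a longer alkyl chain on this carbon would read. Compound 1 and compound 2 differ from compound 3 in more than one place, so this single pair supports no wider pattern across the shared core.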